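Swapping hydroxy for amino on a boron-bearing chalcone

The compounds below may be only part of what the source reports. "The series", "measured", "known", "first", "only" and "open" are said of these compounds alone.

Three related compounds have been tested in a toxicity assay on WI-38 cells (Homo sapiens) for cytotoxicity, read by MTT assay, with a stated time of 48 h; a higher number here means a weaker inhibitor, a lower number a stronger inhibitor. Compound 1 `O=C(/C=C/c1ccc2c(c1)B(O)OC2)c1ccc(O)cc1` gives a limit there, > 100000 nM, and the limit of > 100000 nM in this assay, at which 1 of the 3 values shown sits, marks the edge of what the assay reports. Compound 2 `Nc1ccc(C(=O)/C=C/c2ccc3c(c2)B(O)OC3)cc1` gives 25400 nM in this assay, and compound 3 `O=C(/C=C/c1ccc2c(c1)B(O)OC2)c1cccc(O)c1` gives 26400 nM. The two cores differ as described in 3-hydroxyphenyl in place of 4-hydroxyphenyl on a carbonyl carbon, a difference that brought an at least 3.7-fold lower number from compound 1 to compound 3 (0.57 log units; beyond the scatter). Between compound 2 and compound 3 the gap is a 1.0-fold higher number from compound 2 to compound 3 (0.02 log units; within the scatter), so the two values are read as alike.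

The change from compound 1 to compound 2 is amino in place of hydroxy on an aromatic carbon, and it brought an at least 3.9-fold lower number from compound 1 to compound 2 (0.59 log units; beyond the scatter); as the starting value was a limit, the true size of that step is not known. Compound 4 `Nc1cccc(C(=O)/C=C/c2ccc3c(c2)B(O)OC3)c1` has not yet been measured. It differs from compound 3 by amino in place of hydroxy on an aromatic carbon, the same kind of change, though here the place is meta to a large group rather than para to a large group. The expected step in this assay is a 1.8-fold lower number from compound 3 to compound 4 (0.25 log units; within the scatter). That step is kept modest since compound 3 already gives 26400 nM well inside the range the assay reports. The earlier step, from compound 1 to compound 2, starts from a value the assay does not resolve, so it does not show how far the number can drop. The estimate for compound 4 in this assay is 15000 nM, expected to lie between 5000 nM and 40000 nM.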

Compound 4, half-maximal inhibitory concentration: 25300 nM
Beside the measured number, compound 4's estimate is 1.7-fold (0.23 log units) below it, within the range that was stated.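

Putting amino in place of hydroxy on the core of compound 3 gave a 1.0-fold lower number from compound 3 to compound 4 (0.02 log units; within the scatter) in this assay, so the change does not carry over in the same size from one core to the other: the same change on two cores in this assay, an at least 3.9-fold lower number (0.59 log units; beyond the scatter) from compound 1 to compound 2 and a 1.0-fold lower number (0.02 log units; within the scatter) from compound 3 to compound 4, at least 3.7-fold (0.57 log units) apart, beyond the scatter of two such steps The other new steps fit this picture, with 3-aminophenyl in place of 4-aminophenyl giving a 1.0-fold lower number from compound 2 to compound 4 (0.00 log units; within the scatter) and 3-aminophenyl in place of 4-hydroxyphenyl giving an at least 3.9-fold lower number from compound 1 to compound 4 (0.59 log units; beyond the scatter), which leaves compound 2, compound 3 and compound 4 reading alike while only compound 1 stands apart. What this does not show is how large the step on the core of compound 1 really is or why the two cores differ, as that step starts from a limit and not from a number: the limit of > 100000 nM in this assay, at which 1 of the 4 values shown sits.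

Among the compounds shown here, with only two examples of this swap, no general rule for the series can be drawn from them. Going by these compounds, it remains open whether another group on the same aromatic ring, such as a methoxy group, a carboxylic acid or a dimethylamino group, would keep the number in the range shared by compound 2, compound 3 and compound 4, or would move it towards the limit seen for compound 1.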